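This account rests on a few compounds, and the source may have more. Where it says the series, first, only, none or still open, it means among the compounds named here.

Measured so far:
compound 1, `COc1ccc(N(C)Cc2nc3cc(C(F)(F)F)ccc3nc2-c2ccccc2)cc1OC`, 8000 nM
compound 2, `CCN(Cc1nc2cc(C(F)(F)F)ccc2nc1-c1ccccc1)c1ccc(F)cc1`, 3000 nM
compound 3, `CCN(Cc1nc2cc(C(F)(F)F)ccc2nc1-c1ccccc1)c1ccc(OC(F)(F)F)cc1`, 5000 nM

In an assay on isolated protein for inhibition of Dihydrofolate reductase (Homo sapiens), read by spectrophotometry (on this read-out lower numbers stand for stronger inhibition and higher numbers for weaker inhibition), compound 3 stands second highest of the three numbers; its nearest neighbour is compound 1 and its furthest is compound 2, and both gaps lie within the usual scatter. Compound 4, `CCN(Cc1nc2cc(C(F)(F)F)ccc2nc1-c1ccccc1)c1ccc(OC)c(OC)c1`, is not yet measured. It differs from compound 3 in one place: 3,4-dimethoxyphenyl in place of 4-(trifluoromethoxy)phenyl on an amine nitrogen. Going by the values given here, the only measured step that touches the group on this amine nitrogen is a 1.7-fold higher number from compound 2 to compound 3 (0.22 log units; within the scatter), which is small. Compound 1 carries the same 3,4-dimethoxyphenyl on its amine nitrogen but differs elsewhere, so only its value can be set beside compound 3. For compound 4 a step of about a 1.3-fold higher number from compound 3 to compound 4 (0.11 log units; within the scatter) is therefore expected, not beyond the scatter. Compound 4 is estimated at 6500 nM, within 3000 nM to 14000 nM.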

Compound 4, inhibition constant: 4000 nM
The estimate for compound 4 lay 1.6-fold (0.21 log units) above the measured number; low and high end bracket the measured number.
By their numbers in this assay, from the lowest: compounds 2, 4, 3 and 1 (each within the scatter of the next, the first and the last beyond it).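

In this assay, changing the phenyl group on this amine nitrogen again moves the number little, with a 1.3-fold lower number from compound 3 to compound 4 (0.10 log units; within the scatter) and a 1.3-fold higher number from compound 2 to compound 4 (0.12 log units; within the scatter), so the 4-fluorophenyl, 4-(trifluoromethoxy)phenyl and 3,4-dimethoxyphenyl compounds all lie within the scatter of one another. The other group on this nitrogen now gets its first reading: methyl in place of hydrogen on the saturated chain carbon gives a 2.0-fold lower number from compound 1 to compound 4 (0.30 log units; within the scatter), also no clear effect. Nothing available accounts for these small steps. Still open, from the compounds shown here alone, is whether a carboxylic acid or an amine on this phenyl group, or a longer chain on the nitrogen, would give a step beyond the scatter.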